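The compounds below may be only part of what the source reports. "The series", "measured", "known", "first", "only" and "open" are said of these compounds alone.

Measured in a functional assay on MDA-MB-231 cells (Homo sapiens) for antiproliferative activity, read by MTT assay, with a stated time of 48 h; on this read-out higher numbers stand for weaker inhibition of growth and lower numbers for stronger inhibition of growth:
- compound 1 `CCCOC(=O)N1N=C(c2ccccc2)CC1c1cc(OC)c(OC)c(OC)c1`: 14400 nM
- compound 2 `CCCOC(=O)N1N=C(c2cccc(OC)c2)CC1c1cc(OC)c(OC)c(OC)c1`: 12500 nM
- compound 3 `CCOC(=O)N1N=C(c2ccc(OC)cc2)CC1c1cc(OC)c(OC)c(OC)c1`: 2660 nM

Compound 3 has the lowest of the three numbers, and its gaps to compound 1 and compound 2 both lie beyond the scatter. The next compound is compound 4 `CCCOC(=O)N1N=C(c2ccc(OC)cc2)CC1c1cc(OC)c(OC)c(OC)c1`. The change is methyl in place of hydrogen on a saturated chain carbon, two bonds along the chain from an oxygen next to a carbonyl group: methyl in place of hydrogen on a saturated chain carbon, which turns ethoxy into propoxy.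

Going by the values given here, no measured step shows this change directly. Among the compounds with values here, the only step in hand, a 1.2-fold lower number from compound 1 to compound 2 (0.06 log units; within the scatter), is a different change, and it stays within the scatter. It does suggest that the values of the propoxy compounds can sit close together. Compound 1 at 14400 nM and compound 2 at 12500 nM both carry propoxy and both have higher numbers than compound 3, so some movement toward those numbers is expected, though these data cannot show how much. The expected change in this assay is a 1.9-fold higher number from compound 3 to compound 4 (0.27 log units; within the scatter), a modest step toward weaker inhibition of growth. For compound 4 the estimated value is 5000 nM, with an expected range of 1800 nM to 13000 nM.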

Compound 4, concentration for 50% growth inhibition: 20400 nM
The estimate for compound 4 lay 4.1-fold (0.61 log units) below the measured number; the measured number lies above the stated range.
By their numbers in this assay, from the lowest: compound 3; then compounds 2, 1 and 4 (each within the scatter of the next).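

In this assay, ethoxy turning into propoxy through methyl in place of hydrogen on a saturated chain carbon, two bonds along the chain from an oxygen next to a carbonyl group, gives a 7.7-fold higher number from compound 3 to compound 4 (0.88 log units; beyond the scatter), so with 4-methoxyphenyl in place this one methyl moves the number beyond the scatter, toward weaker inhibition of growth. With propoxy held fixed, the other changes stay within the scatter: 4-methoxyphenyl in place of 3-methoxyphenyl gives a 1.6-fold higher number from compound 2 to compound 4 (0.21 log units; within the scatter), and methoxy in place of hydrogen on an aromatic carbon gives a 1.4-fold higher number from compound 1 to compound 4 (0.15 log units; within the scatter), so the three propoxy compounds show no order among themselves and the ester chain is the only place where a single change has registered so far, in this one pair. Nothing at hand accounts for the size of the chain step.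

As far as these compounds go, whether the same ethoxy to propoxy change carries the same weight with phenyl or 3-methoxyphenyl in place of 4-methoxyphenyl stays open. Also open, from the compounds shown here alone, is how a shorter methoxy ester, a longer butoxy chain, or an amine at the end of the chain would read.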